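From oxan-4-yl to 1-methylpiperidin-4-yl on a shared core

The compounds below may be only part of what the source reports. "The series", "measured", "known", "first", "only" and "open" are said of these compounds alone.

Compound 1 `CCc1ccc(N(CC(C)C)S(=O)(=O)c2ccc3c(c2)C(O)CC(C2CCOCC2)O3)cc1` gives 4.12
Compound 2 `CC(C)CN(c1cc2ccccc2s1)S(=O)(=O)c1ccc2c(c1)C(O)CC(C1CCOCC1)O2` gives 3.92
Compound 3 `CC(C)CN(c1ccc(F)cc1F)S(=O)(=O)c1ccc2c(c1)C(O)CC(C1CCOCC1)O2` gives 3.53

These values come from a physicochemical assay for lipophilicity, at pH 7.4 (on this read-out higher numbers stand for higher lipophilicity and lower numbers for lower lipophilicity), and compound 1 shares the upper end of the three with compound 2, as a number 0.20 log units lower from compound 1 to compound 2 (within the scatter) shows, while a number 0.59 log units lower from compound 1 to compound 3 (beyond the scatter) marks a gap beyond the scatter. Compound 4 `CCc1ccc(N(CC(C)C)S(=O)(=O)c2ccc3c(c2)C(O)CC(C2CCN(C)CC2)O3)cc1` has not yet been measured. It carries 1-methylpiperidin-4-yl in place of oxan-4-yl on a saturated ring carbon, with 1-methylpiperidin-4-yl in place of oxan-4-yl on a saturated ring carbon as the count of that change. The measured steps, a number 0.39 log units lower from compound 2 to compound 3 (beyond the scatter) among them, are all changes on a sulfonamide nitrogen, so none speaks directly to this place. The largest of them, a number 0.59 log units lower from compound 1 to compound 3 (beyond the scatter) in size, gives only a scale. The expectation therefore rests on the structural change itself and points to a lower number, beyond the scatter. The expected step is a number 1.42 log units lower from compound 1 to compound 4 (beyond the scatter) by this estimate, larger than any measured so far. In this assay compound 4 is expected at 2.7 with an estimated range from 2 to 3.4 for the measurement.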

Compound 4, distribution coefficient: 2.67
Compound 4: middle estimate off by 0.03 log units, on the high side; measured number inside the range.
By their numbers in this assay, from the lowest: compound 4; then compound 3; then compounds 2 and 1 (each within the scatter of the next).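

In this assay, the first change shown on a saturated ring carbon, 1-methylpiperidin-4-yl in place of oxan-4-yl, gives a number 1.45 log units lower from compound 1 to compound 4 (beyond the scatter), a larger step than any change on the sulfonamide nitrogen, the largest of which is a number 0.59 log units lower from compound 1 to compound 3 (beyond the scatter). The two groups match in the counts computed from the structures, each being one six-membered non-aromatic ring with 1 hetero atom, 0 hydrogen-bond donors, 1 hydrogen-bond acceptor and no net charge, so those counts do not separate them even though the read-out does. Nothing measured here accounts for the size of this step.

The compounds shown pair this change only with 4-ethylphenyl on the sulfonamide nitrogen, so its size alongside 1-benzothiophen-2-yl or 2,4-difluorophenyl remains open. Also open, going by these compounds, is how this carbon would read with piperidin-4-yl lacking the methyl group, or with a carboxylic acid on the oxan-4-yl ring.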